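The source may hold more compounds than are shown below. What is called first, only, known or untested is meant among the compounds shown, and "the series" means these compounds.

The measured compounds:

Compound 1 `C#Cc1ccccc1N/N=N/c1ccc(C(=N)N)cc1`; in a functional assay on OVCAR-3 cells (Homo sapiens) for antiproliferative activity, read by WST assay, with a stated time of 72 h (a lower number here means a stronger inhibitor of growth, a higher number a weaker inhibitor of growth), compound 1 reports only a limit, > 25000 nM.
Compound 2 `N=C(N)c1ccc(/N=N/Nc2cccc(C#Cc3ccc(F)cc3)c2)cc1`; in this assay compound 2 gives 5000 nM.
Compound 3 `COc1ccc(C#Cc2cccc(N/N=N/c3ccc(C(=N)N)cc3)c2)cc1`; in this assay compound 3 gives 5200 nM.

Compound 2 holds the lowest of the two numbers, with compound 3 nearest; the gap between the two lies within the scatter. Compound 4 `N=C(N)c1ccc(/N=N/Nc2cccc(C#Cc3ccccc3)c2)cc1` differs from compound 2 by hydrogen in place of fluoro on an aromatic carbon. Among the compounds with values here, the one measured step that exchanges this same fluoro, a 1.0-fold higher number from compound 2 to compound 3 (0.02 log units; within the scatter), stayed within the scatter, so swapping the fluoro for hydrogen is expected to move this assay no further than the scatter in either direction. Compound 4 is therefore estimated at 5500 nM, between 2000 nM and 15000 nM. The expected step is a 1.1-fold higher number from compound 2 to compound 4 (0.04 log units; within the scatter).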

Compound 4, concentration for 50% growth inhibition: 6500 nM
Compound 4: middle estimate off by 1.2-fold (0.07 log units), on the low side; low and high end bracket the measured number.
By their numbers in this assay, from the lowest: compounds 2, 3 and 4 (each within the scatter of the next). At a limit, above all of these: compound 1.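

Compound 4 adds the unsubstituted reference that the earlier pair lacked: in this assay, hydrogen in place of fluoro gives a 1.3-fold higher number from compound 2 to compound 4 (0.11 log units; within the scatter) and hydrogen in place of methoxy gives a 1.3-fold higher number from compound 3 to compound 4 (0.10 log units; within the scatter). At this place, para to a large group, neither fluoro nor methoxy is therefore separated from hydrogen in this reading. The data shown offer no explanation for this flat result. Going by these compounds, what stays open is whether an amine, a carboxylic acid or a trifluoromethyl group at the same place would depart from these values.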